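The compounds below may be only part of what the source reports. "The series", "measured", "known", "first", "only" and "open" are said of these compounds alone.

In an assay for positive allosteric modulation of metabotropic glutamate receptor 3 (Rattus norvegicus) (a lower number here means that less compound is needed, a higher number that more compound is needed for the effect), compound 1 `COc1cc(OCCCCOc2ccc(C(=O)CC(C)(C)C)c(O)c2C)cc(C(=O)O)c1` gives 703 nM. Compound 2 `Cc1ccc(OC[C@H](C)COc2ccc(C(=O)CC(C)(C)C)c(O)c2C)cc1C(=O)O` reaches only the limit of the measurement, > 10000 nM, so its true position is not known; this limit is the limit of > 10000 nM in this assay, at which 1 of the 2 values shown sits. Compound 3 `COc1ccccc1OC[C@H](C)COc1ccc(C(=O)CC(C)(C)C)c(O)c1C` differs from compound 2 in one place: 2-methoxyphenyl in place of 3-carboxy-4-methylphenyl on an oxygen on a saturated carbon. Among the compounds with values here, no measured step between related compounds is at hand, and given the limit on compound 2 the expected step is an at least 1.2-fold lower number from compound 2 to compound 3 (0.09 log units; that floor lies within the scatter), which cannot be placed beyond the scatter. Compound 3 is therefore estimated at 8000 nM, within a range from 2000 nM to 30000 nM.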

Compound 3, half-maximal effective concentration: "not active" (no number reported)
The entry for compound 3 holds no number; no gap can be computed for the estimate.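

Compound 3 is reported as "not active", with no number, and compound 2 is held at a limit, so no step can be read between them: the limit of > 10000 nM in this assay, at which 1 of the 3 values shown sits. The compounds shown leave open how 2-methoxyphenyl and 3-carboxy-4-methylphenyl truly compare in this assay.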